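The source may hold more compounds than are shown below. What is called first, only, known or untested is meant among the compounds shown, and "the series" means these compounds.

Measured compounds:
compound 1 `O=S(=O)(CC1=NCCS1)C1=NNCC1c1ccccc1`, a functional assay, tested at 75 ug/mL; on this read-out higher numbers stand for a stronger effect at the one concentration tested and lower numbers for a weaker effect: "not active" (no number reported)
compound 2 `O=S(=O)(CC1=NCCS1)c1n[nH]cc1-c1ccccc1`, this assay: "not active" (no number reported)
compound 3 `COc1ccc(C2=NOC(c3ccc(C)cc3)C2S(=O)(=O)CC2=NCCS2)cc1`, this assay: 49.7%

Going by the values given here, compound 1 stands without a single number in this assay, as does compound 2; only compound 3 gives a number, and no step between measured compounds connects it to compound 1. Compound 4 `O=S(=O)(CC1=NCCO1)C1=NNCC1c1ccccc1` differs from compound 1 by a group of 5 heavy atoms (3 carbon, 1 nitrogen, 1 oxygen; one five-membered non-aromatic ring with 2 hetero atoms) in place of a group of 5 heavy atoms (3 carbon, 1 nitrogen, 1 sulfur; one five-membered non-aromatic ring with 2 hetero atoms), on a saturated chain carbon bound to a sulfonyl sulfur. Nothing measured here shows what such a change does, so the expectation rests on compound 1 alone: a step of no clear size or direction beyond the scatter, and a good chance that compound 4, like compound 1, is reported without a number. Compound 4 is expected to give about 10%, between 0% and 35%.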

Compound 4, a percentage reported as activity, at one concentration (the size of the read-out at that concentration, not a potency): "not active" (no number reported)
The entry for compound 4 holds no number; there is nothing to compare the estimate with.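

Compound 1 and compound 4 both stand without a number in this assay; no new step can be read from them, and no evidence bears on this result. The compounds shown leave open what the exchange of sulfur for oxygen in this group does to a measurable effect.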